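Hydrazone and imine analogues of a benzyloxy-coumarin series

The source may report more compounds than this note shows. Statements on the series, on what has been measured and on what is new or still open speak of the compounds shown alone.

Measured compounds:
compound 1 `O=c1cc(/C=N\c2ccccc2O)c2ccc(OCc3ccccc3)cc2o1` – 469000 nM
compound 2 `N/N=C\c1cc(=O)oc2cc(OCc3ccccc3)cc(OCc3ccccc3)c12` – 36500 nM
compound 3 `O=c1cc(/C=N\Nc2ccccc2)c2ccc(OCc3ccccc3)cc2o1` – 416000 nM

In a functional assay, read by spectrophotometry, with a stated time of 5 min (on this read-out higher numbers stand for weaker inhibition and lower numbers for stronger inhibition), compound 2 gives the lowest of the three numbers; the steps from compound 2 to compound 3 and to compound 1 are both beyond the scatter, so compound 2 stands apart as the strongest inhibitor among the measured compounds. Compound 4 `O=c1cc(/C=N\Nc2ccc([N+](=O)[O-])cc2)c2c(OCc3ccccc3)cc(OCc3ccccc3)cc2o1` is not yet measured. It differs from compound 2 by 4-nitrophenyl in place of hydrogen on an amine nitrogen.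

Among the compounds with values here, only one measured step is known, a 1.1-fold lower number from compound 1 to compound 3 (0.05 log units; within the scatter); it exchanges one aryl for another on a double-bonded nitrogen and says nothing about replacing hydrogen by an aryl on an amine nitrogen. Compound 2 and compound 3 differ in two places at once, so their values cannot be read as a single step; they show only that the aryl-bearing hydrazone with one benzyloxy group gives a far higher number than the free hydrazone with two. On this basis a weakening step is expected, a 2.5-fold higher number from compound 2 to compound 4 (0.39 log units; beyond the scatter), with wide uncertainty. Compound 4 is estimated at 90000 nM, in the range 25000 nM to 320000 nM.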

Compound 4, half-maximal inhibitory concentration: 419000 nM
The estimate for compound 4 lay 4.7-fold (0.67 log units) below the measured number; the measured number lies above the stated range.
By their numbers in this assay, from the lowest: compound 2; then compounds 3, 4 and 1 (each within the scatter of the next).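

In this assay, within the data shown here, 4-nitrophenyl in place of hydrogen on the amine nitrogen gives an 11-fold higher number from compound 2 to compound 4 (1.06 log units; beyond the scatter), the only reading here of a change at this nitrogen with the core held constant. Among these compounds, the low number of compound 2 is therefore lost through this single change, with the core of compound 2 untouched, whereas the earlier exchange of groups on a double-bonded nitrogen stayed within the scatter and gave no sign of a step this large. No measurement available here bears on what lies behind the step.

On these data alone, whether a small group such as methyl or acetyl on this amine nitrogen also raises the number remains open. The compounds shown also do not separate the contribution of the nitro group from that of the aromatic ring that carries it.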